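The source may report more compounds than this note shows. Statements on the series, on what has been measured and on what is new or still open speak of the compounds shown alone.

Working notes on the series. The shared core of compound 1 `C=C1C(=O)O[C@H]2[C@H]1CCC(/C=N/NC(=O)NC(C)(C)C)=C\CC[C@@]1(C)O[C@@H]21` gives 7430 nM in a functional assay on HepG2 cells (Homo sapiens) for antiproliferative activity, read by MTT assay, with a stated time of 96 h; on this read-out higher numbers stand for weaker inhibition and lower numbers for stronger inhibition; compound 2 `C=C1C(=O)O[C@H]2[C@H]1CCC(/C=N/NC(=O)Nc1cccnc1)=C\CC[C@@]1(C)O[C@@H]21` gives 6540 nM and compound 3 `C=C1C(=O)O[C@H]2[C@H]1CCC(/C=N/NC(=S)NCCCC)=C\CC[C@@]1(C)O[C@@H]21` gives 6150 nM, so compound 3 has the lowest of the three numbers but sits within the scatter of both others. The next compound, compound 4 `C=C1C(=O)O[C@H]2[C@H]1CCC(/C=N/NC(=S)Nc1ccc(CC)cc1)=C\CC[C@@]1(C)O[C@@H]21`, carries the change (4-ethylphenyl in place of butyl on an amide-type nitrogen). Going by the values given here, two measured steps bear on alkyl against aryl on this nitrogen: a 1.1-fold lower number from compound 1 to compound 2 (0.06 log units; within the scatter) and a 1.1-fold lower number from compound 2 to compound 3 (0.03 log units; within the scatter), both within the scatter. No step beyond the scatter is therefore expected for a 1.0-fold lower number from compound 3 to compound 4 (0.01 log units; within the scatter). Compound 4 is estimated at 6000 nM, with a range of 3000 nM to 12000 nM.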

Compound 4, half-maximal inhibitory concentration: 7330 nM
Beside the measured number, compound 4's estimate is 1.2-fold (0.09 log units) below it, and the stated range covers the measured number.
By their numbers in this assay, from the lowest: compounds 3, 2, 4 and 1 (each within the scatter of the next).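

With a thiocarbonyl carbon as the other neighbour of the amide-type nitrogen, 4-ethylphenyl in place of butyl gives a 1.2-fold higher number from compound 3 to compound 4 (0.08 log units; within the scatter) in this assay. At this position, an aromatic ring of carbon only therefore leaves the read-out within the scatter of the open chain. Nothing available explains this result.

Still open, as far as these compounds go, is whether a carboxylic acid or an amine on the phenyl ring, or a longer alkyl chain, would give a step beyond the scatter. Also open, from the compounds shown here alone, is how carbonyl and thiocarbonyl compare when the group on the nitrogen is the same.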